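This account rests on a few compounds, and the source may have more. Where it says the series, first, only, none or still open, it means among the compounds named here.

Of the compounds shown here, three of a shared core have been tested in an assay on membranes from HeLa cells for displacement of a labelled ligand from adenosine receptor A3 (Homo sapiens), read by scintillation counting, with a stated time of 180 min, tested at 1 uM; a higher number here means more inhibition at the concentration tested (going by the name of the read-out), a lower number less inhibition. Compound 2 `CCSC(=O)C1=C(C)NC(=O)NC1c1ccco1` gives 14%, the highest of the three numbers. Compound 1 `CC1=C(C(=O)OCc2ccccc2)C(c2ccco2)NC(=O)N1` gives 3%, and compound 3 `CCSC(=O)C1=C(C)NC(=O)NC1c1ccoc1` gives 1%. Going by the values given here, the only measured step between neighbours is a number 13 percentage points lower from compound 2 to compound 3 (beyond the scatter), where the furan attachment moves; the ester end of the molecule is untouched there, so that step does not speak to the change now in question. Compound 4 `CC1=C(C(=O)OCC2CC2)C(c2ccco2)NC(=O)N1` differs from compound 2 in one place: cyclopropylmethoxy in place of ethylsulfanyl on a carbonyl carbon. Among the compounds with values here, compound 1 carries a benzyloxy group on the same carbonyl carbon and gives the low value shown, while compound 2 with its ethylsulfanyl group gives the higher one; no single-change step ties those two together, so this is only what the two values show. Within the data shown here, with no direct precedent, compound 4 is expected to fall near the lower of the two, roughly a number 8 percentage points lower from compound 2 to compound 4 (within the scatter) from compound 2. The estimate for compound 4 in this assay is 6%, with a range from 0% to 16%.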

Compound 4, a percentage reported as inhibition, at one concentration (the size of the read-out at that concentration, not a potency): 1%
Estimate against measurement, compound 4: 5 percentage points above, and the stated range covers the measured number.
By their numbers in this assay, from the lowest: compounds 3, 4 and 1 (each within the scatter of the next); then compound 2.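

In this assay, going by these compounds alone, putting cyclopropylmethoxy in place of ethylsulfanyl on the carbonyl carbon gives a number 13 percentage points lower from compound 2 to compound 4 (beyond the scatter) and is the first direct measure of a change at this position. Cyclopropyl in place of phenyl at the far end of the group on that carbon gives a number 2 percentage points lower from compound 1 to compound 4 (within the scatter), so these two rings cannot be told apart in this measurement. Nothing available here offers a reason for either step.

The change from compound 2 to compound 4 replaces the sulfur with an oxygen and alters the attached chain at the same time, so the compounds shown cannot say which of the two matters. As far as these compounds go, an ethoxy group on the same carbonyl carbon would separate these two changes, and its effect remains open.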